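The source may hold more compounds than are shown below. What is called first, only, known or untested is meant among the compounds shown, and "the series" means these compounds.

Measured so far:
compound 1, `COc1nc(-c2nc3ccccc3n2C)cc(-c2ccccc2)c1C#N`: 300000 nM
compound 2, `COc1nc(-c2nc3ccccc3n2C)cc(-c2ccc(Cl)cc2)c1C#N`: 145000 nM
compound 3, `COc1nc(-c2nc3ccccc3n2C)cc(-c2ccc(C)cc2)c1C#N`: 295000 nM

All three share one core and differ only in a single group attached to it. In a functional assay on aorta (Rattus norvegicus, strain Wister) (on this read-out higher numbers stand for weaker inhibition and lower numbers for stronger inhibition), compound 3 gives 295000 nM, the second highest of the three numbers; compound 1 sits within the scatter of it, while compound 2 lies a modest step away (a 2.0-fold higher number from compound 2 to compound 3 (0.31 log units; beyond the scatter)). Compound 4, `COc1nc(-c2nc3ccccc3n2C)cc(-c2cccs2)c1C#N`, is not yet measured. It differs from compound 3 by thiophen-2-yl in place of 4-methylphenyl on an aromatic carbon. Going by the values given here, none of the measured steps covers a change of this kind: a 2.1-fold lower number from compound 1 to compound 2 (0.32 log units; beyond the scatter) and a 1.0-fold lower number from compound 1 to compound 3 (0.01 log units; within the scatter) only exchange a hydrogen for chloro or methyl on an aromatic carbon, and even the larger of them was modest. With the whole series confined to a narrow band, compound 4 is expected to stay close to compound 3, with an estimated step of a 1.2-fold lower number from compound 3 to compound 4 (0.07 log units; within the scatter). The estimate for compound 4 is 250000 nM, within 110000 nM to 600000 nM.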

Compound 4, half-maximal inhibitory concentration: 312000 nM
The estimate for compound 4 lay 1.2-fold (0.10 log units) below the measured number; the range from low to high includes it.
By their numbers in this assay, from the lowest: compound 2; then compounds 3, 1 and 4 (each within the scatter of the next).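

In this assay the position on the shared core, ortho to a cyano group, accepts a five-membered aromatic ring with a sulfur atom as readily as a six-membered carbon ring: thiophen-2-yl matches phenyl (a 1.0-fold higher number from compound 1 to compound 4 (0.02 log units; within the scatter)) and 4-methylphenyl (a 1.1-fold higher number from compound 3 to compound 4 (0.02 log units; within the scatter)). Only 4-chlorophenyl stands apart, by a modest step (a 2.2-fold higher number from compound 2 to compound 4 (0.33 log units; beyond the scatter)). Nothing available explains this flat result. Going by these compounds, it remains open whether an amine or a carboxylic acid at this position would move the number out of this narrow band.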